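This account rests on a few compounds, and the source may have more. Where it says the series, first, only, none or still open, it means among the compounds named here.

Measured compounds in this study:

Compound 1, `CC(=O)OCOC(=O)N(C)/N=N/c1ccc(Br)cc1`: 0.283 h
Compound 2, `Cc1nccn1CCOC(=O)[C@H](C)c1ccc(-c2ccccc2)c(F)c1`: 0.633 h
Compound 3, `CCCN(CCC)Cc1cccc(C(=O)OCCOCn2cnc3c(=O)[nH]c(N)nc32)c1`: 0.0133 h

All three compounds were tested in an ADME assay on a cell-free system (plasma, Homo sapiens) for metabolic stability; a lower number here means that the compound disappears faster, a higher number that the compound lasts longer. Among the three numbers, compound 1 holds the second highest place with 0.283 h. Its nearest neighbour is compound 2, which gives 0.633 h, a gap that lies beyond the scatter of this assay. The furthest from it is compound 3, which gives 0.0133 h, again well beyond the scatter. Within the data shown here, the three compounds share no common core and no pair of them differs in only one place, so no single structural step between measured compounds can be read from these values.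

Compound 4, `CC(=O)OCOC(=O)N(C)/N=N/c1ccc(C#N)cc1`, is the next compound to be measured. It is built on the core of compound 1 and differs from it in one place: cyano in place of bromo on an aromatic carbon. Among the measured compounds shown here, no measured pair in this set shows how such an exchange changes the half-life, so the expectation rests on compound 1 alone. The step of a 1.1-fold higher number from compound 1 to compound 4 (0.03 log units; within the scatter) is expected to be small, with no clear direction beyond the scatter. Compound 4 is therefore estimated at 0.3 h, with a range from 0.12 h to 0.75 h.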

Compound 4, half-life: 0.117 h
Estimate against measurement, compound 4: 2.6-fold (0.41 log units) above; the whole stated range lies above it.
By their numbers in this assay, from the lowest: compound 3; then compound 4; then compound 1; then compound 2.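

In this assay, among these compounds, replacing bromo with cyano on an aromatic carbon, para to a large group, gives a 2.4-fold lower number from compound 1 to compound 4 (0.38 log units; beyond the scatter), the first step in this set that can be read between two compounds differing in one place. It shows that this position on the shared core is not silent: a change confined to this one substituent, with the rest of the core of compound 1 untouched, moves the half-life beyond the scatter, toward faster disappearance. Nothing measured here accounts for the direction or size of this step, which remains an observation from a single pair.

With only bromo and cyano shown at this place, it remains open how other groups there, such as chloro, methoxy, an amine or a carboxylic acid, would compare with these two, and whether the half-life would follow any order across such a series. From the compounds shown here alone, it also remains open whether the same exchange would give a step of similar size and direction on a core other than that of compound 1, or with a different chain in place of the acetoxymethyl ester portion.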